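Exchanging an Aromatic Group: Compound 1 to Compound 4

This account rests on a few compounds, and the source may have more. Where it says the series, first, only, none or still open, it means among the compounds named here.

compound 1 `COc1ccccc1-n1cc(COc2c(/C=C\C(=O)O)ccc(OC)c2CC=C(C)C)nn1` - "not determined" (no result reported)
compound 2 `COc1ccc(/C=C\C(=O)O)c(OCc2cn(-c3ccccc3F)nn2)c1CC=C(C)C` - 11000 nM
compound 3 `COc1ccc(-n2cc(COc3c(/C=C\C(=O)O)ccc(OC)c3CC=C(C)C)nn2)cc1` - "not determined" (no result reported)

In a functional assay on T47D cells (Homo sapiens) for cytotoxicity, read by MTT assay, with a stated time of 24 h (on this read-out higher numbers stand for weaker inhibition and lower numbers for stronger inhibition), compound 1 has no single number to stand on, and compound 3 likewise lacks one. Only compound 2 gives a number, 11000 nM. The change leading to compound 4 `COc1ccc(/C=C\C(=O)O)c(OCc2cn(-c3ccc(CO)cc3)nn2)c1CC=C(C)C` is 4-(hydroxymethyl)phenyl in place of 2-methoxyphenyl on an aromatic nitrogen, with 4-(hydroxymethyl)phenyl in place of 2-methoxyphenyl on an aromatic nitrogen. No measured step among these compounds shows what such an exchange does in this assay. Within the data shown here, no direction can therefore be argued, and the only number to reason from is the one held by compound 2 at 11000 nM. For compound 4 the expected value is 18000 nM, with an estimated range from 6000 nM to 55000 nM.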

Compound 4, half-maximal inhibitory concentration: 40000 nM
Compound 4: middle estimate off by 2.2-fold (0.35 log units), on the low side, within the range that was stated.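

In this assay an exchange on this aromatic nitrogen now has a measured size: 4-(hydroxymethyl)phenyl in place of 2-fluorophenyl gives a 3.6-fold higher number from compound 2 to compound 4 (0.56 log units; beyond the scatter) and so weaker inhibition, a modest step beyond the usual scatter. Among these compounds, this single pair is the only reading of such an exchange at this position. Nothing at hand explains the step. The compounds shown leave open whether the hydroxyl of the entering group or the place it occupies on the phenyl ring sets this step. From the compounds shown here alone, how 4-(aminomethyl)phenyl or 4-carboxyphenyl would read on the same nitrogen also remains open.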